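Swapping the benzimidazole group on compound 3

A few compounds are considered here, and "the series" means these few. Any claim that something is new, unique, unknown or untested is made for them only; others in the source may bear on it.

compound 1 `CCN(CC)CCn1c(N)c(-c2nc3ccccc3n2C)c2nc(C#N)c(C#N)nc21`: 3250 nM
compound 2 `CN(C)CCCn1c(N)c(-c2nc3ccccc3n2C)c2nc(C#N)c(C#N)nc21`: 11300 nM
compound 3 `CCN(CC)CCCn1c(N)c(-c2nc3ccccc3n2C)c2nc(C#N)c(C#N)nc21`: 4470 nM

All three values come from a functional assay on HL60/MX2 cells (Homo sapiens) for antiproliferative activity, read by MTT assay, with a stated time of 48 h; on this read-out lower numbers stand for stronger inhibition and higher numbers for weaker inhibition. Compound 3 cannot be told apart from compound 1, as a 1.4-fold higher number from compound 1 to compound 3 (0.14 log units; within the scatter) shows, and it lies clearly away from compound 2, with a 2.5-fold lower number from compound 2 to compound 3 (0.40 log units; beyond the scatter).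

Compound 4 `CCN(CC)CCCn1c(N)c(-c2nc3cc(Cl)ccc3[nH]2)c2nc(C#N)c(C#N)nc21` keeps the 3-(diethylamino)propyl group of compound 3 and changes a different part of the molecule: 5-chloro-1H-benzimidazol-2-yl in place of 1-methyl-1H-benzimidazol-2-yl on an aromatic carbon. The new 5-chloro-1H-benzimidazol-2-yl group replaces 1-methyl-1H-benzimidazol-2-yl on an aromatic carbon, next to the ring atom that bears an amino group.

Going by the values given here, no measured step touches this group. All three altered only the amine chain, the largest being a 3.5-fold higher number from compound 1 to compound 2 (0.54 log units; beyond the scatter), so they show how far chain changes move the numbers but give no direction for this swap. A lower number in this assay is tentatively expected, with a step larger than the chain steps, and this remains a judgement. The expected change is a 3.4-fold lower number from compound 3 to compound 4 (0.54 log units; beyond the scatter). For compound 4 the estimated value is 1300 nM, with an expected range of 250 nM to 6000 nM.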

Compound 4, half-maximal inhibitory concentration: 2460 nM
Compound 4: the middle estimate sits 1.9-fold (0.28 log units) below what was measured; measured number inside the range.
By their numbers in this assay, from the lowest: compounds 4, 1 and 3 (each within the scatter of the next); then compound 2.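

Moving away from the amine chain, the swap at this aromatic carbon, next to the ring atom that bears an amino group, gives a 1.8-fold lower number from compound 3 to compound 4 (0.26 log units; within the scatter) in this assay, so this position accepts 5-chloro-1H-benzimidazol-2-yl in place of 1-methyl-1H-benzimidazol-2-yl without a change that can be told from scatter. Going by these compounds alone, the swap does two things at once, removing the methyl group from the ring nitrogen and adding a chlorine, and the single step cannot separate them. No measured evidence accompanies this result to explain it.

The plain 1H-benzimidazol-2-yl group and 5-chloro-1-methyl-1H-benzimidazol-2-yl would each carry only one of the two changes, so the compounds shown leave open what each contributes alone. They also leave open whether a larger group at this position, such as a 5-methoxy-1H-benzimidazol-2-yl, would move the number further.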